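A methoxy on the fused ring of compound 1

The source may report more compounds than this note shows. Statements on the series, on what has been measured and on what is new or still open speak of the compounds shown alone.

Among the measured compounds shown here, compound 1 `COc1ccc(NC(=O)C(=O)c2cn(C(C)C)c3ccccc23)cn1` is one of two compounds measured in a functional assay on FaDu cells (Homo sapiens) for cytotoxicity, read by MTT assay, with a stated time of 72 h; a higher number here means that more compound is tolerated, a lower number that less compound is tolerated. In this assay compound 1 gives 85 nM, the lowest of the two numbers. Its neighbour, compound 2 `COc1ccc(NC(=O)C(=O)c2cn(CC3CCO3)c3ccccc23)cn1`, gives 686 nM in this assay; the step of an 8.1-fold higher number from compound 1 to compound 2 (0.91 log units; beyond the scatter) exchanges the group on the aromatic nitrogen of the shared core. Compound 3 `COc1ccc2c(C(=O)C(=O)Nc3ccc(OC)nc3)cn(C(C)C)c2c1` has not yet been measured. It differs from compound 1 in one place: methoxy in place of hydrogen on an aromatic carbon. For the measured compounds named here, the only measured step, an 8.1-fold higher number from compound 1 to compound 2 (0.91 log units; beyond the scatter), concerns a different position, the substituent on the aromatic nitrogen, and says nothing direct about a methoxy on an aromatic carbon of the fused or bridged system of two rings. Going by the values given here, no measured pair shows the effect of this change, so the expectation rests on the value of compound 1 alone. Because compound 1 gives 85 nM and nothing in the data points to a shift beyond the scatter, compound 3 is expected to show a step of a 1.4-fold higher number from compound 1 to compound 3 (0.15 log units; within the scatter). The estimate for compound 3 is 120 nM, with a range from 35 nM to 450 nM.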

Compound 3, concentration lethal to 50% of the cells: > 10000 nM
Compound 3: only a limit was reported (the forecaster's own chance of this, stated with the estimate: 3%); middle value at least 83-fold (1.92 log units) away from the limit.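

Among the compounds shown here, compound 3 shows what the earlier compounds could not: the aromatic carbon of the fused system, and not only the aromatic nitrogen, governs the reading in this assay. Adding a methoxy in place of hydrogen on this carbon, meta to a fused ring and para to a fused ring, gives an at least 110-fold higher number from compound 1 to compound 3 (2.07 log units; beyond the scatter), so a group of only 2 heavy atoms at this place is enough to separate compound 3 sharply from compound 1. The reading for compound 3 is a limit of the assay and not a number, so the step gives only a lower bound on the true size of the change: the limit of > 10000 nM in this assay, at which 1 of the 3 values shown sits.

The compounds shown leave open whether this outcome belongs to methoxy itself or would also follow from a fluorine, a hydroxyl or an amine on the same carbon. They also leave open whether methoxy on the other carbons of this ring, or together with the (oxetan-2-yl)methyl on the aromatic nitrogen, would give the same result.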